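A few compounds are considered here, and "the series" means these few. Any claim that something is new, unique, unknown or untested is made for them only; others in the source may bear on it.

Among the measured compounds shown here, compound 2 `CC(C)NC(=O)c1cc(Oc2cccc(NC(=S)Nc3ccc(OC(F)(F)F)cc3)c2)ccn1` is one of two compounds measured in a functional assay on MDA-MB-231 cells (Homo sapiens) for cytotoxicity, read by MTT assay, with a stated time of 48 h; a lower number here means a stronger inhibitor, a higher number a weaker inhibitor. In this assay compound 2 gives only a limit of the assay, > 100000 nM. Compound 1 `O=C(NCc1ccccc1)c1cc(Oc2cccc(NC(=S)Nc3ccc(Cl)cc3)c2)ccn1` likewise reaches only the limit, > 100000 nM in this assay. Both values therefore sit at the limit of > 100000 nM in this assay, at which 2 of the 2 values shown sit, and nothing here separates the two compounds from each other. Compound 3 `O=C(NCc1ccccc1)c1cc(Oc2cccc(NC(=S)Nc3ccc(OC(F)(F)F)cc3)c2)ccn1` is not yet measured. It differs from compound 2 by benzyl in place of isopropyl on an amide-type nitrogen. Compound 1 already carries the benzylcarbamoyl group and shows no measurable inhibition, so this change alone gives no sign of a gain. For compound 3 the step from compound 2 is expected to be none beyond the scatter, a step that the limit leaves unreadable from compound 2 to compound 3, with the likely outcome again being a limit rather than a number. Compound 3 is therefore estimated at 150000 nM, in the range from 50000 nM to 500000 nM.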

Compound 3, half-maximal inhibitory concentration: > 100000 nM
Compound 3: no number, only a limit (the forecaster's own chance of this, stated with the estimate: 85%); the middle value lies beyond the limit too.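

In this assay, among the compounds shown here, compound 3 gives only a limit, > 100000 nM, so no step from compound 1 or compound 2 to it can be read. The compounds shown leave open whether benzyl or isopropyl, or trifluoromethoxy or chloro, makes any difference to cytotoxicity, as every value is a limit: the limit of > 100000 nM in this assay, at which 3 of the 3 values shown sit.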